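This account rests on a few compounds, and the source may have more. Where it says the series, first, only, none or still open, it means among the compounds named here.

Working notes on the series. Within the data shown here, in a functional assay on MCF7 cells (Homo sapiens) for antiproliferative activity, read by CellTiter-Glo, with a stated time of 5 days (on this read-out higher numbers stand for weaker inhibition and lower numbers for stronger inhibition), compound 2 `N#Cc1ccc(/C(=C(\c2ccc(/C=C/C(=O)O)cc2)c2ccc3nccn3c2)C2CCC2)c(Cl)c1` gives 15 nM, the highest of the three numbers so far. Compound 3 `N#Cc1cc(Cl)ccc1/C(=C(\c1ccc(/C=C/C(=O)O)cc1)c1ccc2nccn2c1)C1CCC1` gives 5.9 nM, and compound 1 `O=C(O)/C=C/c1ccc(/C(=C(\c2ccc(F)cc2Cl)C2CCC2)c2ccc3nccn3c2)cc1` gives 4.4 nM.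

Compound 4 `N#Cc1ccc(/C(=C(\c2ccc(/C=C/C(=O)O)cc2)c2ccc(-c3cn[nH]c3)cc2)C2CCC2)c(Cl)c1` differs from compound 2 at a single place, on a double-bonded chain carbon bound to an aromatic carbon and a double-bonded chain carbon: a group of 11 heavy atoms (9 carbon, 2 nitrogen; one five-membered aromatic ring with 2 hetero atoms, one six-membered aromatic ring of carbon only) in place of a group of 9 heavy atoms (7 carbon, 2 nitrogen; one five-membered aromatic ring with 2 hetero atoms, one six-membered aromatic ring with 1 hetero atom), on a double-bonded chain carbon bound to an aromatic carbon and a double-bonded chain carbon. The entering group is 4-(1H-pyrazol-4-yl)phenyl, and the leaving group has no common name.

Among the measured compounds shown here, three measured steps give the scale of change so far: a 3.4-fold higher number from compound 1 to compound 2 (0.53 log units; beyond the scatter), a 1.3-fold higher number from compound 1 to compound 3 (0.13 log units; within the scatter) and a 2.5-fold lower number from compound 2 to compound 3 (0.41 log units; beyond the scatter). All three change a different group from the one exchanged here, so they bear on this step only indirectly. For the measured compounds named here, no measured pair tests this exchange, and the data give no direction for it.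

With only modest or smaller steps seen elsewhere in the series, no shift beyond the scatter is assumed in this assay, and the range is kept wide on both sides. The expected change is a 1.3-fold lower number from compound 2 to compound 4 (0.10 log units; within the scatter). For compound 4 the estimated value is 12 nM, with an expected range from 4 nM to 40 nM.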

Compound 4, half-maximal inhibitory concentration: 2.2 nM
Compound 4: the middle estimate sits 5.5-fold (0.74 log units) above what was measured; measured number below the stated range.
By their numbers in this assay, from the lowest: compounds 4, 1 and 3 (each within the scatter of the next, the first and the last beyond it); then compound 2.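

In this assay, among these compounds, 4-(1H-pyrazol-4-yl)phenyl on a double-bonded chain carbon bound to an aromatic carbon and a double-bonded chain carbon gives a 6.8-fold lower number from compound 2 to compound 4 (0.83 log units; beyond the scatter), the largest step so far, and the first to show that the number also responds to a change at this place rather than only to changes in the halogenated and cyano-bearing aryl group. Among the compounds shown here, the exchange swaps a six-membered aromatic ring with 1 hetero atom for one of carbon only, enlarges the group and adds a hydrogen-bond donor, so this single step shows only that the group can be replaced and the number still fall, with these differences acting together. The series offers no measurement that explains the size or direction of this step.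

A plain phenyl group or a 4-aminophenyl group at this place would help separate the contribution of the pyrazole from that of the carbon-only ring. From the compounds shown here alone, it also remains open whether the same exchange gives a step of similar size alongside the 2-chloro-4-fluorophenyl group of compound 1 or the 4-chloro-2-cyanophenyl group of compound 3.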